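Naphthyl-triazole spirodienones: chloro removal on the aryl ring

The compounds below may be only part of what the source reports. "The series", "measured", "known", "first", "only" and "open" are said of these compounds alone.

Measured so far:
compound 1 `O=C1C=CC2(C=C1)OCC(=O)N2c1nc(-c2ccc3ccccc3c2)nn1-c1ccc(Cl)cc1` — 720 nM
compound 2 `Cc1ccc(-n2nc(-c3ccc4ccccc4c3)nc2N2C(=O)C(C)OC23C=CC(=O)C=C3)cc1` — 530 nM
compound 3 `CC1CN(c2nc(-c3ccc4ccccc4c3)nn2-c2ccccc2)C2(C=CC(=O)C=C2)O1` — 260 nM

Three compounds sharing the naphthyl-triazole spirodienone core have been run in a functional assay on HeLa cells (Homo sapiens) for antiproliferative activity, with a stated time of 5 days; a lower number here means a stronger inhibitor, a higher number a weaker inhibitor. Compound 1 gives 720 nM, the highest of the three numbers. Compound 2, at 530 nM, sits within the scatter of compound 1, so no order between those two can be read. Going by the values given here, compound 3, at 260 nM, lies beyond the scatter from compound 1 and is the lowest number in the set; it differs from compound 1 in more than one place, so no single step can be drawn from it.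

The next compound, compound 4 `O=C1C=CC2(C=C1)OCC(=O)N2c1nc(-c2ccc3ccccc3c2)nn1-c1ccccc1`, is reached from compound 1 by one change: hydrogen in place of chloro on an aromatic carbon. Cut one bond further out, the difference reads 4-chlorophenyl to phenyl, with the change on an aromatic carbon para to a large group. Among the compounds with values here, no measured pair in this assay isolates that change. Compound 3 also carries a phenyl on the same nitrogen and gives the lowest number, but its other differences from compound 1 leave that unattributed.

For compound 4 the expected step of a 1.4-fold lower number from compound 1 to compound 4 (0.16 log units; within the scatter) is small, toward a lower number, and not clearly beyond the scatter. Compound 4 is therefore estimated at 500 nM, within the range 200 nM to 1200 nM.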

Compound 4, half-maximal inhibitory concentration: 120 nM
Compound 4: the middle estimate sits 4.2-fold (0.62 log units) above what was measured; the whole stated range lies above it.
By their numbers in this assay, from the lowest: compound 4; then compound 3; then compounds 2 and 1 (each within the scatter of the next).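

In this assay, going by these compounds alone, hydrogen in place of chloro on an aromatic carbon, para to a large group, gives a 6.0-fold lower number from compound 1 to compound 4 (0.78 log units; beyond the scatter) and so supplies the first pair that differs in one place. The earlier compounds shown here left this position unattributed, whereas this pair shows that the difference from 4-chlorophenyl to phenyl alone, with the rest of the core of compound 1 unchanged, moves the number beyond the scatter. That statement rests on this single pair, and nothing at hand gives a measured reason for the step.

Going by these compounds, whether the lower number simply follows the loss of chloro, or whether it would also appear with fluoro, methoxy, an amine or a carboxylic acid on that same aromatic carbon, remains open. On these data alone, it also remains open whether the same exchange of chloro for hydrogen would give a step of similar size on the core of compound 3, where a 4-chlorophenyl partner would be needed to read it.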